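A few compounds are considered here, and "the series" means these few. Any claim that something is new, unique, unknown or untested is made for them only; others in the source may bear on it.

Compound 1 `CCCCCCCNC[C@@H]1OC[C@H](N)[C@H]1O` is the parent of this short series. In a functional assay on MCF7 cells (Homo sapiens) for antiproliferative activity, read by MTT assay, with a stated time of 72 h (on this read-out higher numbers stand for weaker inhibition and lower numbers for stronger inhibition), compound 1 gives > 128000 nM, which is a limit of the assay and not a number. Compound 3 `CCCCCCCCNC[C@@H]1OC[C@H](N)[C@H]1O` is the next homologue along the chain, and in this assay compound 3 gives > 128000 nM, again a limit. Compound 2 `CCCCCCCCCCCCNC[C@@H]1OC[C@H](N)[C@H]1O` carries the longest chain, and in this assay compound 2 gives 12600 nM. The readable steps are an at least 10-fold lower number from compound 1 to compound 2 (1.00 log units; beyond the scatter) and an at least 10-fold higher number from compound 2 to compound 3 (1.00 log units; beyond the scatter), while a step that the two limits leave unreadable from compound 1 to compound 3. Compound 4 `CCCCCCCNC[C@@H]1OC[C@H](N)[C@@H]1O` is still to be measured. Against compound 1: the two compounds have the same atoms and bonds and differ only in configuration as drawn: 1 of 3 stereo elements differ; a stereocentre at a saturated ring carbon is drawn R in compound 1 and S in compound 4. Every measured step runs along the chain and none touches a stereocentre, so none bears on this change and no direction can be drawn from them. Compound 4 is therefore expected to give 200000 nM in this assay, within 100000 nM to 500000 nM. The estimated step is a step that the limit leaves unreadable from compound 1 to compound 4.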

Compound 4, half-maximal inhibitory concentration: > 128000 nM
Compound 4 ended at the assay's limit; the forecaster's own chance of this, stated with the estimate: 80%; the middle value is on the limit's open side.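

Compound 1 and compound 4 both end at a limit and not at a number, so no step between them can be read: the limit of > 128000 nM in this assay, at which 3 of the 4 values shown sit.

From the compounds shown here alone, whether the configuration at that saturated ring carbon changes activity on a chain as long as that of compound 2 remains open.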